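One Fluorine Removed from Compound 3

This account rests on a few compounds, and the source may have more. Where it says the series, first, only, none or still open, it means among the compounds named here.

Compound 1 `Cc1ccc(-c2cc(COC3(C(F)(F)F)Oc4ccccc4C=C3C(=O)O)on2)cc1`: 30100 nM
Compound 2 `O=C(O)C1=Cc2ccccc2OC1(OCc1cc(-c2ccc3ccccc3c2)no1)C(F)(F)F`: a limit, > 150000 nM
Compound 3 `O=C(O)C1=Cc2ccccc2OC1(OCc1cc(-c2ccc(F)cc2F)no1)C(F)(F)F`: a limit, > 150000 nM

In a functional assay on MCF7 cells (Homo sapiens) for inhibition, read by MTT assay, with a stated time of 24 h (a lower number here means a stronger inhibitor, a higher number a weaker inhibitor), compound 1 gives 30100 nM. For compound 2 the assay returns only a limit, > 150000 nM. Compound 3 likewise returns only a limit, > 150000 nM. Compound 3 therefore stands at the weak end of the three: two of the three values, including its own, sit at the limit of > 150000 nM in this assay, at which 2 of the 3 values shown sit. Both replacements of the 4-methylphenyl group cost potency: an at least 4.9-fold higher number from compound 1 to compound 2 (0.69 log units; beyond the scatter) and an at least 4.9-fold higher number from compound 1 to compound 3 (0.69 log units; beyond the scatter). Between the two limited compounds, a step that the two limits leave unreadable from compound 2 to compound 3.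

Compound 4 `O=C(O)C1=Cc2ccccc2OC1(OCc1cc(-c2ccc(F)cc2)no1)C(F)(F)F` differs from compound 3 by hydrogen in place of fluoro on an aromatic carbon. Among the compounds with values here, no measured step removes a single fluoro, so the only guide is the loss seen on going from compound 1 to compound 3, where a 4-methylphenyl became a 2,4-difluorophenyl. Compound 4, keeping one fluoro, is expected to remain weak; the estimated step of an at least 1.2-fold lower number from compound 3 to compound 4 (0.09 log units; that floor lies within the scatter) is expected to lie close to the scatter, with a fair chance that the assay again reports only a limit. Compound 4 is estimated at 120000 nM, within 40000 nM to 300000 nM.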

Compound 4, half-maximal inhibitory concentration: 64200 nM
For compound 4 the middle estimate is 1.9-fold (0.27 log units) above the measured one; the range from low to high includes it.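

In this assay, within the data shown here, the single change from 2,4-difluorophenyl to 4-fluorophenyl, hydrogen in place of the fluoro ortho to a large group, gives an at least 2.3-fold lower number from compound 3 to compound 4 (0.36 log units; beyond the scatter), so this one position separates a readable value from a limit. The same 4-fluorophenyl group also compares favourably with the naphthalen-2-yl group, with an at least 2.3-fold lower number from compound 2 to compound 4 (0.36 log units; beyond the scatter), which means that a fluorinated aryl group at this place in the shared core need not fall out of the measurable range. Compound 4 also gives the first readable size for a fluoro group against the methyl group of compound 1, with a 2.1-fold higher number from compound 1 to compound 4 (0.33 log units; beyond the scatter), and compound 1 remains the strongest of the four in this assay.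

The compounds shown leave open whether a chloro or a methoxy group on the carbon ortho to a large group would also cost potency, or whether the loss is specific to fluoro there. The step between compound 2 and compound 3 cannot be read, and each of these two compounds remains a limit of the assay: the limit of > 150000 nM in this assay, at which 2 of the 4 values shown sit.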